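Swapping Methyl for Chloro in a Solubility Series

A few compounds are considered here, and "the series" means these few. Any claim that something is new, unique, unknown or untested is made for them only; others in the source may bear on it.

In a physicochemical assay for solubility, read by spectrophotometry, in phosphate buffer, with a stated time of 18 h, at pH 7.4 (a lower number here means a less soluble compound, a higher number a more soluble compound), compound 1 `CCc1ccc(-c2nc3c(c(C)nn3-c3ccccc3)c(-c3ccccc3OC(F)(F)F)c2C#N)cc1` gives 9900 nM and compound 2 `CCc1ccc(-c2nc3c(c(C)nn3-c3ccccc3)c(-c3ccc(O)cc3)c2C#N)cc1` gives 5700 nM. Compound 3 `Cc1ccc(-c2nc3c(c(C)nn3-c3ccccc3)c(-c3ccccc3O)c2C#N)cc1` stands highest of the three at 26000 nM, beyond the scatter from both others. Compound 4 `Cc1nn(-c2ccccc2)c2nc(-c3ccc(Cl)cc3)c(C#N)c(-c3ccccc3O)c12` has not been measured. It carries chloro in place of methyl on an aromatic carbon, para to a large group, so 4-methylphenyl becomes 4-chlorophenyl: chloro in place of methyl on an aromatic carbon.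

For the measured compounds named here, only one measured step links two compounds that differ in one place. That step, a 1.7-fold lower number from compound 1 to compound 2 (0.24 log units; within the scatter), lies within the scatter and involves a different pair of groups, 4-hydroxyphenyl in place of 2-(trifluoromethoxy)phenyl. No measurement tests the methyl-to-chloro change itself, so no step beyond the scatter is expected in this assay, and the best guide is the value of compound 3 at 26000 nM. The estimated change is small, a 1.3-fold lower number from compound 3 to compound 4 (0.11 log units; within the scatter). The expected value for compound 4 is 20000 nM, with an estimated range from 8000 nM to 45000 nM.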

Compound 4, solubility: 3800 nM
Estimate against measurement, compound 4: 5.3-fold (0.72 log units) above; measured number below the stated range.
By their numbers in this assay, from the lowest: compounds 4, 2 and 1 (each within the scatter of the next, the first and the last beyond it); then compound 3.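

Methyl and chloro each count as a single heavy atom, and neither adds a ring, a hydrogen-bond donor or acceptor, or a net charge. Even so, at this position, para to a large group, 4-chlorophenyl in place of 4-methylphenyl in this assay gives a 6.8-fold lower number from compound 3 to compound 4 (0.84 log units; beyond the scatter), so this small exchange moves the number beyond the scatter. This is the only step shown that tests this position, and no measurement shown here accounts for the drop.

The compounds shown leave open how other groups at the same position, such as fluoro, methoxy or an amine, would read in this assay. They also leave open whether methyl to chloro gives a step of similar size when other parts of the shared core carry different groups.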